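The source may hold more compounds than are shown below. What is called first, only, known or untested is meant among the compounds shown, and "the series" means these compounds.

Measured compounds:
Compound 1 `CCCN(CCC)c1c(C)nc(-c2c(C)cc(C)cc2OC)nc1OC`: 15 nM
Compound 2 `CCCOc1nc(-c2c(C)cc(C)cc2OC)nc(C)c1N(CCC)CCC`: 53 nM
Compound 3 `CCCN(CCC)c1c(C)nc(-c2c(C)cc(C)cc2OC)nc1OC(C)C`: > 5000 nM

In an in vitro assay on IMR-32 cells for displacement of a labelled ligand from corticotropin-releasing factor receptor 1 (Homo sapiens) (on this read-out higher numbers stand for weaker inhibition and lower numbers for stronger inhibition), compound 1 gives the lowest of the two numbers shown. Compound 2 sits next to it, with a 3.5-fold higher number from compound 1 to compound 2 (0.55 log units; beyond the scatter). Compound 3 gives only a limit of this assay, (the limit of > 5000 nM in this assay, at which 1 of the 3 values shown sits), and not a number. Against that limit the steps read an at least 330-fold higher number from compound 1 to compound 3 (2.52 log units; beyond the scatter) and an at least 94-fold higher number from compound 2 to compound 3 (1.97 log units; beyond the scatter).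

Compound 4 `CCCN(CCC)c1c(CC(C)O)nc(-c2c(C)cc(C)cc2OC)nc1OC` differs from compound 1 by 1-hydroxyethyl in place of hydrogen on a saturated chain carbon bound to an aromatic carbon. Going by the values given here, none of the measured steps touches this place: all three concern the group on the aromatic oxygen. They show that this assay responds strongly to changes elsewhere on the shared core, but they give no direct guide to a 1-hydroxyethyl group on the chain carbon bound to an aromatic carbon. Compound 4 is therefore expected to give a number somewhat higher than compound 1, an expected step of a 4.0-fold higher number from compound 1 to compound 4 (0.60 log units; beyond the scatter). Compound 4 is estimated at 60 nM, in a range from 15 nM to 300 nM.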

Compound 4, inhibition constant: 1150 nM
Compound 4: the middle estimate sits 19-fold (1.28 log units) below what was measured, and the stated range ends below it.
By their numbers in this assay, from the lowest: compound 1; then compound 2; then compound 4. At a limit, above all of these: compound 3.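

In this assay, going by these compounds alone, the saturated chain carbon bound to an aromatic carbon turns out to be a place where the read-out responds strongly, which the earlier steps, all on the group on the aromatic oxygen, could not show. Putting 1-hydroxyethyl in place of hydrogen there gives a 77-fold higher number from compound 1 to compound 4 (1.88 log units; beyond the scatter), a large loss of inhibition from a change of only a few heavy atoms. Nothing shown here accounts for the size of this step.

The compounds shown leave open whether a plain propyl chain in place of the 2-hydroxypropyl would give a similar step, and so whether the oxygen or the chain itself carries the loss. On these data alone, how an amine or a carboxylic acid on this same chain would read in this assay also stays open.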